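Aryl swap on the side chain: compound 1 to compound 3

The source may hold more compounds than are shown below. What is called first, only, known or untested is meant among the compounds shown, and "the series" means these compounds.

Measured in a functional assay (aorta) with Oryctolagus cuniculus as the target; on this read-out higher numbers stand for weaker inhibition and lower numbers for stronger inhibition:
- compound 1 `CC1=C(C)C(=O)C(C(CCCCCC(=O)O)c2ccccc2C)=C(C)C1=O`: 3200 nM
- compound 2 `COc1ccc(C(CCCCCC(=O)O)C2=C(C)C(=O)C(C)=C(C)C2=O)cc1`: 3000 nM

For the measured compounds named here, only two numbers are available in this assay, and compound 1 stands level with compound 2 within the scatter, so neither can be ranked above the other. The next compound to be measured is compound 3 `CC1=C(C)C(=O)C(C(CCCCCC(=O)O)c2cccs2)=C(C)C1=O`. It carries thiophen-2-yl in place of the 2-methylphenyl of compound 1, on the same saturated chain carbon, with the shared core and the acid-bearing chain unchanged: thiophen-2-yl in place of 2-methylphenyl on a saturated chain carbon bound to a double-bonded ring carbon and a saturated chain carbon.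

Going by the values given here, one measured step bears on this change, since it also replaces the aromatic group at that carbon: a 1.1-fold lower number from compound 1 to compound 2 (0.03 log units; within the scatter). That exchange left the number within the scatter. Among the compounds with values here, no thiophene-bearing compound has been measured yet, so this support is indirect and the range is kept wide. In this assay no shift beyond the scatter is expected, and the expected step is a 1.1-fold lower number from compound 1 to compound 3 (0.06 log units; within the scatter). For compound 3 the estimated value is 2800 nM, with an expected range from 1100 nM to 7000 nM.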

Compound 3, half-maximal inhibitory concentration: 760 nM
The estimate for compound 3 lay 3.7-fold (0.57 log units) above the measured number; measured number outside the range, below it.
By their numbers in this assay, from the lowest: compound 3; then compounds 2 and 1 (each within the scatter of the next).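

At the saturated chain carbon bound to a double-bonded ring carbon and a saturated chain carbon, the choice of aromatic group can shift the number in this assay: thiophen-2-yl gives a 4.2-fold lower number from compound 1 to compound 3 (0.62 log units; beyond the scatter) and a 3.9-fold lower number from compound 2 to compound 3 (0.60 log units; beyond the scatter), both pointing to stronger inhibition. The level result for 2-methylphenyl and 4-methoxyphenyl therefore does not extend to every aromatic group at this place. The change replaces a six-membered aromatic ring of carbon only with a five-membered aromatic ring with one hetero atom, and also brings in a hydrogen-bond acceptor, but no supporting data indicate which of these differences, if any, accounts for the step.

From the compounds shown here alone, it remains open whether the lower number is specific to thiophen-2-yl or extends to other five-membered aromatic rings, such as furan-2-yl or thiophen-3-yl, at the same carbon. Also open, going by these compounds, are where unsubstituted phenyl would fall relative to compound 1 and compound 2, and whether the gain from thiophen-2-yl persists with a shorter or longer acid-bearing chain.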